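Carbamate-to-ketone swap at the piperidine nitrogen: efficacy notes

The source may report more compounds than this note shows. Statements on the series, on what has been measured and on what is new or still open speak of the compounds shown alone.

Measured so far:
compound 1, `CCC1(OC(=O)N2CCC(Oc3ncnc(Oc4ccc(S(C)(=O)=O)nc4C)c3F)CC2)CC1`, 83%
compound 2, `Cc1nc(S(C)(=O)=O)ccc1Oc1ncnc(OC2CCN(C(=O)OC3(C(F)(F)F)CCC3)CC2)c1F`, 82%
compound 3, `Cc1nc(S(C)(=O)=O)ccc1Oc1ncnc(OC2CCN(C(=O)OC3(C(F)(F)F)COC3)CC2)c1F`, 84%

All three compounds share one core and differ only in the group on the oxygen next to a carbonyl group. In a functional assay on isolated protein for inhibition of Glucose-dependent insulinotropic receptor (Rattus norvegicus), read by HTRF and cAMP accumulation (a higher number here means a larger maximal response, a lower number a smaller maximal response), compound 3 gives 84%. The steps to it are a number 1 percentage points higher from compound 1 to compound 3 (within the scatter) and a number 2 percentage points higher from compound 2 to compound 3 (within the scatter), and the remaining pair shows a number 1 percentage points lower from compound 1 to compound 2 (within the scatter); none of the three separates from the others, so compound 3 cannot be set apart from compound 1 or compound 2 on these numbers.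

Compound 4, `Cc1nc(S(C)(=O)=O)ccc1Oc1ncnc(OC2CCN(C(=O)C(C)(C)F)CC2)c1F`, is not yet measured in this assay. It differs from compound 3 by 1-fluoro-1-methylethyl in place of (3-(trifluoromethyl)oxetan-3-yl)oxy on a carbonyl carbon. This is a different kind of change from the measured steps, which exchanged one ring for another on the oxygen while keeping the carbamate itself; here the oxygen leaves with the ring and a 1-fluoro-1-methylethyl group sits directly on the carbonyl carbon. Among the compounds with values here, no measured pair covers that. What the measured steps do show is that the maximal response has stayed flat across three quite different groups in this region. On that basis the expected step is a number 2 percentage points lower from compound 3 to compound 4 (within the scatter), with no change beyond the scatter. Compound 4 is therefore estimated at 82%, expected to lie between 68% and 94%.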

Compound 4, largest response reached (reported as efficacy), in percent of the reference or control that the assay uses: 74%
Beside the measured number, compound 4's estimate is 8 percentage points above it; measured number inside the range.
By their numbers in this assay, from the lowest: compounds 4, 2, 1 and 3 (each within the scatter of the next).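

In this assay, the group on the carbonyl carbon can change by more than an exchange of rings on the oxygen: (3-(trifluoromethyl)oxetan-3-yl)oxy leaves with both its oxygen and its ring, 1-fluoro-1-methylethyl enters, and the result is a number 10 percentage points lower from compound 3 to compound 4 (within the scatter). The other two new steps, a number 8 percentage points lower from compound 2 to compound 4 (within the scatter) and a number 9 percentage points lower from compound 1 to compound 4 (within the scatter), are also larger than any step among the three carbamates, yet as each remains within the scatter, this set supports no loss of maximal response on leaving the carbamate. No supporting data bear on the size of these steps.

Still open, as far as these compounds go, is how this assay reads when an amine, or a longer chain without fluorine, stands on the carbonyl carbon, and whether a group of this size keeps the same response once the fluorine of 1-fluoro-1-methylethyl is replaced by hydrogen. From the compounds shown here alone, all four compounds keep the shared core, so the effect of any change outside this position on the maximal response also remains unknown.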